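Sulfonyl series: trifluoromethyl added to the aromatic ring

This account rests on a few compounds, and the source may have more. Where it says the series, first, only, none or still open, it means among the compounds named here.

compound 1 `CS(=O)(=O)N1C(=O)COC12C=CC(=O)C=C2`: 7530 nM
compound 2 `O=C1C=CC2(C=C1)OCC(=O)N2S(=O)(=O)c1ccccc1`: > 10000 nM (a limit)

In a functional assay on HeLa cells (Homo sapiens) for inhibition, read by sulforhodamine B assay, with a stated time of 74 h (a lower number here means a stronger inhibitor, a higher number a weaker inhibitor), compound 1 gives 7530 nM. As far as these compounds go, for compound 2 this assay reports only a limit, > 10000 nM, so where it truly stands is unknown. Going by the values given here, the single measured step, an at least 1.3-fold higher number from compound 1 to compound 2 (0.12 log units; that floor lies within the scatter), ends at the limit of > 10000 nM in this assay, at which 1 of the 2 values shown sits. Compound 3 `O=C1C=CC2(C=C1)OCC(=O)N2S(=O)(=O)c1ccccc1C(F)(F)F` differs from compound 2 by trifluoromethyl in place of hydrogen on an aromatic carbon. Among the compounds with values here, no measured step concerns a substituent on that aromatic ring, so neither direction nor size can be drawn from the data. Compound 3 is therefore expected to stay near the limit, a step that the limit leaves unreadable from compound 2 to compound 3, with an estimated 12000 nM (range 4000 nM to 40000 nM).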

Compound 3, half-maximal inhibitory concentration: 20 nM
For compound 3 the middle estimate is 600-fold (2.78 log units) above the measured one, and the stated range ends above it.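

In this assay, the six-membered aromatic ring on the sulfonyl sulfur proves a highly sensitive position: trifluoromethyl in place of hydrogen on an aromatic carbon, ortho to a large group, gives an at least 500-fold lower number from compound 2 to compound 3 (2.69 log units; beyond the scatter). Compound 2 is recorded only as a limit, > 10000 nM. That makes the step a floor, with its full size unknown: the limit of > 10000 nM in this assay, at which 1 of the 3 values shown sits.

As far as these compounds go, whether the gain belongs to trifluoromethyl itself or would also come with a methyl group, a chlorine atom or a nitrile on the same carbon stays open. Equally open, from the compounds shown here alone, is how an amine or a carboxylic acid would fare at this place.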